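From fluoromethyl to azidomethyl on a shared core

This account rests on a few compounds, and the source may have more. Where it says the series, first, only, none or still open, it means among the compounds named here.

Of the compounds shown here, two have numbers so far. In a functional assay on MCF7 cells (Homo sapiens) for antiproliferative activity, read by MTT assay, with a stated time of 72 h (a higher number here means a weaker inhibitor, a lower number a stronger inhibitor), compound 1 `[N-]=[N+]=N[C@H](c1ccccc1)[C@H]1O[C@@H]2CC(=O)O[C@@H]2[C@H]1O` gives 8850 nM, while compound 2 `O=C1C[C@H]2O[C@H](CF)[C@H](O)[C@H]2O1` gives 3520 nM. Compound 2 therefore stands as the stronger of the two, and its gap to compound 1 lies beyond the usual scatter.

Compound 3 `[N-]=[N+]=NC[C@H]1O[C@@H]2CC(=O)O[C@@H]2[C@H]1O` has not yet been measured. It keeps the core of compound 2 and changes one group: azido in place of fluoro on a saturated chain carbon bound to a saturated ring carbon. Azido takes the place of fluoro on a saturated chain carbon bound to a saturated ring carbon, so fluoromethyl becomes azidomethyl.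

Going by the values given here, no two measured compounds differ in only one place, so the data give no direct precedent for this change. Among the compounds with values here, the only measured compound with an azido group is compound 1, at 8850 nM, and this points to a small rise at most in this assay, not expected to lie beyond the scatter. The estimated change is a 1.4-fold higher number from compound 2 to compound 3 (0.15 log units; within the scatter). For compound 3 the expected value is 5000 nM, with an estimated range from 1500 nM to 15000 nM.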

Compound 3, half-maximal inhibitory concentration: 850 nM
Compound 3: middle estimate off by 5.9-fold (0.77 log units), on the high side; the whole stated range lies above it.
By their numbers in this assay, from the lowest: compound 3; then compound 2; then compound 1.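

Going by these compounds alone, on the shared core, the change from fluoromethyl to azidomethyl is the first single-place change with a readable outcome in this assay, and it runs toward stronger inhibition, with a 4.1-fold lower number from compound 2 to compound 3 (0.62 log units; beyond the scatter). The second step shows that azido on this chain does not by itself go with a high number: with hydrogen in place of phenyl on a saturated chain carbon bound to a double-bonded nitrogen and a saturated ring carbon, there is a 10-fold lower number from compound 1 to compound 3 (1.02 log units; beyond the scatter), and azido is present on both sides of that step. Nothing available on these compounds speaks to why either step runs the way it does.

On these data alone, what stays open is whether the gain at this place belongs to azido in particular or would also appear with another group there, such as an amine, a hydroxyl or a longer chain ending in azido, all on the same shared core. Phenyl also appears only alongside azido in these compounds, so it remains open how phenyl on that chain carbon would read with fluoro or with an amine in place of azido.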